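Moving Two Methyl Groups Around a Pyridine Ring

This account rests on a few compounds, and the source may have more. Where it says the series, first, only, none or still open, it means among the compounds named here.

Compound 1 `CC[C@H](C)[C@@H]1C(=O)N[C@H](C2Cc3ccccc3C2)C(=O)N1[C@@H](C(=O)N(C)C)c1ccc(C)[n+]([O-])c1` gives 1 mL.min-1.g-1 in an in vitro ADME assay on microsomes from liver (Macaca fascicularis) for metabolic stability; a lower number here means slower removal, a higher number faster removal of the compound.
Compound 2 `CC[C@H](C)[C@@H]1C(=O)N[C@H](C2Cc3ccccc3C2)C(=O)N1[C@@H](C(=O)N(C)C)c1cnc(C)cc1C` gives 32 mL.min-1.g-1 in this assay.
Compound 3 `CC[C@H](C)[C@@H]1C(=O)N[C@H](C2Cc3ccccc3C2)C(=O)N1[C@@H](C(=O)NC)c1cnc(C)cc1C` gives 20 mL.min-1.g-1 in this assay.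

Among these three, compound 2 has the highest number in this assay. Its nearest neighbour is compound 3, reached by a change on the amide nitrogen: a 1.6-fold lower number from compound 2 to compound 3 (0.20 log units; within the scatter). Its furthest neighbour is compound 1, which carries a different six-membered ring: a 32-fold higher number from compound 1 to compound 2 (1.51 log units; beyond the scatter).

Compound 4 `CC[C@H](C)[C@@H]1C(=O)N[C@H](C2Cc3ccccc3C2)C(=O)N1[C@@H](C(=O)N(C)C)c1cc(C)cnc1C` keeps every atom of compound 2 but joins them differently: 2,5-dimethylpyridin-3-yl in place of 4,6-dimethylpyridin-3-yl on a saturated chain carbon bound to an amide-type nitrogen in a ring and a carbonyl carbon. The measured steps do not test a change of this kind. The step from compound 1 to compound 2 exchanged one aromatic ring for another with different atoms, and the step from compound 2 to compound 3 touched only the amide nitrogen. Neither moved methyl groups to other positions on the same ring, so there is no direct guide.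

With nothing pointing either way, compound 4 is expected to stay close to compound 2, and the step of no change at the digits printed from compound 2 to compound 4 (within the scatter) is estimated to lie within the scatter. In this assay compound 4 is therefore estimated at 32 mL.min-1.g-1, with a range from 12 mL.min-1.g-1 to 85 mL.min-1.g-1.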

Compound 4, intrinsic clearance in microsomes: 13 mL.min-1.g-1
Compound 4: middle estimate off by 2.5-fold (0.39 log units), on the high side; the range from low to high includes it.
By their numbers in this assay, from the lowest: compound 1; then compounds 4, 3 and 2 (each within the scatter of the next, the first and the last beyond it).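

Rearranging the two methyl groups on the pyridine ring, with no atom added or lost, is enough to shift the number in this assay: 2,5-dimethylpyridin-3-yl in place of 4,6-dimethylpyridin-3-yl gives a 2.5-fold lower number from compound 2 to compound 4 (0.39 log units; beyond the scatter). The earlier compounds shown here could not show this, since none of them kept the same ring atoms and changed only where the methyl groups sit. The new ring still leaves a wide distance to the oxygen-bearing ring of compound 1, with a 13-fold higher number from compound 1 to compound 4 (1.11 log units; beyond the scatter), so the rearrangement covers only part of the distance that a change of ring atoms can span, and nothing available here explains the effect of the rearrangement.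

The compounds shown leave open how 2,5-dimethylpyridin-3-yl behaves when the amide carries a hydrogen in place of one methyl, as in compound 3, and which of its two methyl groups accounts for the step. They also leave open what a pyridine ring with a single methyl, or with a methoxy group or a fluorine in place of one methyl, would give.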